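The source may hold more compounds than are shown below. What is called first, only, known or untested is meant among the compounds shown, and "the series" means these compounds.

Compound 1, `O=C(/C=C/c1cc(Br)ccc1O)c1ccc(Br)cc1`, is the starting point of the set. In a functional assay on MCF7 cells (Homo sapiens) for antiproliferative activity, read by sulforhodamine B assay, with a stated time of 72 h, tested at 10 uM (on this read-out higher numbers stand for a weaker effect at the one concentration tested and lower numbers for a stronger effect), compound 1 gives 28.7%. Compound 2, `Cc1ccc(C(=O)/C=C/c2cc(Br)ccc2O)cc1`, is its direct partner: the two differ by methyl in place of bromo on an aromatic carbon, and in this assay compound 2 gives 27.3%. The step that this exchange made, a number 1.4 percentage points lower from compound 1 to compound 2 (within the scatter), is small, so on this read-out the two open-chain compounds cannot be told apart.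

Compound 3, `N#CC1=C(N)Oc2ccc(Br)cc2C1CC(=O)c1ccc(Br)cc1`, carries a different core. In this assay compound 3 gives 47.2%, the highest of the three numbers, and its distance to compound 1 and to compound 2 lies beyond the scatter in both cases. How the core of compound 3 differs from the core of compound 1 is not broken down here.

Compound 4, `Cc1ccc(C(=O)CC2C(C#N)=C(N)Oc3ccc(Br)cc32)cc1`, has not yet been measured in this assay. It stands to compound 3 as compound 2 stands to compound 1: the difference is methyl in place of bromo on an aromatic carbon, and the place of the exchange reads the same in both pairs. Because the earlier step of a number 1.4 percentage points lower from compound 1 to compound 2 (within the scatter) stayed within the scatter, the step from compound 3 to compound 4 is expected to be about as small, a number 1.2 percentage points lower from compound 3 to compound 4 (within the scatter). On that basis compound 4 is estimated to give 46% in this assay, with a likely range from 35% to 58%.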

Compound 4, a percentage reported as activity, at one concentration (the size of the read-out at that concentration, not a potency): 69%
For compound 4 the middle estimate is 23 percentage points below the measured one, outside the stated range (above it).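

In this assay, the exchange of 4-bromophenyl for 4-methylphenyl did not behave on the core of compound 3 as it did on the core of compound 1; here it gave a number 21.8 percentage points higher from compound 3 to compound 4 (beyond the scatter). The two readings of this one change do not agree: the same change on two cores in this assay, a number 1.4 percentage points lower (within the scatter) from compound 1 to compound 2 and a number 21.8 percentage points higher (beyond the scatter) from compound 3 to compound 4, 23.2 percentage points apart, beyond the scatter of two such steps. Among the compounds shown here, this shows that, in this series, the near-absence of a step on the open-chain pair cannot be carried over to the core of compound 3, and that on this core the methyl compound has the weaker effect at the one concentration tested, but it does not show why the two cores part, and with only one pair on each core and one concentration, it says nothing about how the change would read on a third core or whether the gap would hold at other concentrations.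

The compounds shown carry only bromo or methyl at this place, so it remains open how a chlorine atom, a methoxy group or an amine there would read on either core. Also open, as far as these compounds go, is what would happen on each core if the bromo group that all four compounds share on the other aromatic ring were replaced.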